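The compounds below may be only part of what the source reports. "The series", "measured", "known", "first", "only" and "open" are said of these compounds alone.

Measured compounds in an ADME assay on HEK293 cells (Homo sapiens) for cytotoxicity, read by CCK-8 assay, with a stated time of 48 h; a higher number here means a weaker inhibitor, a lower number a stronger inhibitor:
compound 1 `COc1ccc(/C=C\c2cc(OC)c(OC)c(OC)c2)cc1OCc1ccc(CN2CC(C(=O)O)C2)cc1` gives > 50000 nM
compound 2 `COc1ccc(/C=C\c2cc(OC)c(OC)c(OC)c2)cc1OCc1ccc(CN2CCCCC2C(=O)O)cc1` gives > 50000 nM

Compound 1 is known in this assay only as a limit, > 50000 nM, which is the edge of the assay and not a number. Compound 2 likewise sits at a limit in this assay, > 50000 nM. Within the data shown here, the only measured step, a step that the two limits leave unreadable from compound 1 to compound 2, therefore cannot be read in size or direction; both values rest at the limit of > 50000 nM in this assay, at which 2 of the 2 values shown sit.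

Compound 3 `COc1ccc(/C=C\c2cc(OC)c(OC)c(OC)c2)cc1OCc1ccc(CN2CCCCC2C(=O)NCCN)cc1` is the next compound. It differs from compound 1 by 2-((2-aminoethyl)carbamoyl)piperidin-1-yl in place of 3-carboxyazetidin-1-yl on a saturated chain carbon bound to an aromatic carbon. Among the measured compounds shown here, the one step that touches the same position, from compound 1 to compound 2, gives no readable size, so the expected step is not anchored by any measured number; what the two limits show is that neither compound 1 nor compound 2 reached a measurable value in this assay. On that basis compound 3 is expected to sit near the same limit, with the step that the limit leaves unreadable from compound 1 to compound 3 expected to be small. The estimate for compound 3 in this assay is 60000 nM, expected within 20000 nM to 200000 nM.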

Compound 3, half-maximal inhibitory concentration: > 50000 nM
Compound 3: no number, only a limit (the forecaster's own chance of this, stated with the estimate: 75%); the middle value lies beyond the limit too.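

In this assay compound 3 gives > 50000 nM, which is a limit and not a number. Among these compounds, no step from compound 1 or compound 2 to compound 3 can therefore be read in size or direction, and all three compounds rest at the same edge: the limit of > 50000 nM in this assay, at which 3 of the 3 values shown sit. The compounds shown leave open what actual value any of them has in this assay.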